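A few compounds are considered here, and "the series" means these few. Any claim that something is new, unique, unknown or untested is made for them only; others in the source may bear on it.

The series shares one core; compound 1 is `COc1cc(-c2ncnn2-c2ccccc2)cc(OC)c1OC`. In a functional assay on A549 cells (Homo sapiens) for antiproliferative activity, read by MTT assay, with a stated time of 72 h (on this read-out lower numbers stand for stronger inhibition and higher numbers for weaker inhibition), compound 1 reaches only the limit of the assay, > 10000 nM, which is a limit and not a number. Compound 2, `CCOc1cccc(-c2ncnn2-c2cc(OC)c(OC)c(OC)c2)c1`, likewise gives only a limit in this assay, > 10000 nM. Compound 3, `CCOc1ccc(-c2ncnn2-c2cc(OC)c(OC)c(OC)c2)cc1`, gives in this assay 100 nM. So two of the three values sit at the limit of > 10000 nM in this assay, at which 2 of the 3 values shown sit, and compound 1 stands among them, without a number of its own to set against compound 3.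

Compound 4 is `COc1cc(-c2ncnn2-c2cccc(F)c2)cc(OC)c1OC`. Its difference from compound 1 is fluoro in place of hydrogen on an aromatic carbon. The fluoro enters on an aromatic carbon of a six-membered aromatic ring of carbon only, meta to a large group; cut one bond further out, phenyl becomes 3-fluorophenyl. Going by the values given here, no measured pair in this set differs in only one place, so no measured step can be held up beside this change. Since compound 1 shows only a limit, the step to compound 4 in this assay is expected to be none beyond the scatter, that is a step that the limit leaves unreadable from compound 1 to compound 4. Compound 4 is accordingly expected to give about 15000 nM in this assay, within 3000 nM to 60000 nM, and most likely to be reported once more as a limit rather than a number.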

Compound 4, half-maximal inhibitory concentration: > 10000 nM
Compound 4: a limit, no number (the forecaster's own chance of this, stated with the estimate: 65%); the middle value is on the limit's open side.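

Compound 1 and compound 4 both give a limit and not a number in this assay, so no step can be read between them: the limit of > 10000 nM in this assay, at which 3 of the 4 values shown sit.

The compounds shown leave open whether fluoro in place of hydrogen on an aromatic carbon changes activity in this assay at all, and what numbers compound 1 and compound 4 would carry.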